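The source may report more compounds than this note shows. Statements on the series, on what has been measured and on what is new or still open speak of the compounds shown alone.

Compound 1, `Clc1ccc(C(c2ccccc2)N2CCN(c3ncnc4c3cnn4-c3ccccc3)CC2)cc1`, was tested in a functional assay on cells (Rhabdomyosarcoma cell, Homo sapiens) for cytotoxicity; a higher number here means a weaker inhibitor, a lower number a stronger inhibitor. In this assay compound 1 gives > 25000 nM, which is a limit of the assay rather than a measured number. Among the measured compounds shown here, compound 2, `Cc1ccccc1C(c1sccc1C)N1CCN(c2ncnc3c2cnn3-c2ccccc2)CC1`, is the only other compound with a value, and in this assay compound 2 gives > 25000 nM, again a limit. The whole picture of the measured compounds is summed up by the limit of > 25000 nM in this assay, at which 2 of the 2 values shown sit, so no difference between them can be read from the numbers. Compound 3, `c1ccc(-c2ccc(C(c3ccccc3)N3CCN(c4ncnc5c4cnn5-c4ccccc4)CC3)cc2)cc1`, is not yet measured. It differs from compound 1 in one place: phenyl in place of chloro on an aromatic carbon. For the measured compounds named here, with no measured step to lean on, the expected step from compound 1 to compound 3 is none beyond the scatter. Compound 3 is therefore estimated at 25000 nM, in a range from 10000 nM to 80000 nM. The expected step is a number no higher from compound 1 to compound 3 (the limit leaves the size open), and a limit rather than a number is the most likely outcome.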

Compound 3, half-maximal inhibitory concentration: > 25000 nM
Compound 3 was reported as a limit; the forecaster's own chance of this, stated with the estimate: 80%; the middle value sits exactly at the limit.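

Among the compounds shown here, compound 1 and compound 3 both give a limit rather than a number, so no step between them can be read: the limit of > 25000 nM in this assay, at which 3 of the 3 values shown sit. The compounds shown leave open whether phenyl in place of chloro changes anything in this assay, and which change to the shared core, if any, would give a measurable value.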